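The compounds below may be only part of what the source reports. "The series", "measured", "known", "first", "only" and "open" are said of these compounds alone.

Compound 1 `O=C(Nc1cccc(-n2cc(-c3ccncc3)c(-c3ccc(Cl)c(O)c3)n2)c1)Nc1ccc(Cl)c(Cl)c1` and compound 2 `O=C(Nc1cccc(-n2cc(-c3ccncc3)c(-c3ccc(Cl)c(O)c3)n2)c1)Nc1cc(C(F)(F)F)cc(C(F)(F)F)c1` share one core and differ only in the ring carried on the far side of the urea. In a functional assay on NCI-H522 cells (Homo sapiens) for inhibition, read by sulforhodamine B assay, with a stated time of 48 h (on this read-out higher numbers stand for weaker inhibition of growth and lower numbers for stronger inhibition of growth), compound 1 gives 10600 nM, while compound 2 gives 2510 nM. Of the two numbers in hand, compound 1 stands highest, so compound 2 is the stronger grower-inhibitor of the pair.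

Compound 3 `O=C(Nc1cccc(-n2cc(-c3ccncc3)c(-c3ccc(Cl)c(O)c3)n2)c1)Nc1ccc(Cl)c(C(F)(F)F)c1` is the untested relative. Its change from compound 1 is trifluoromethyl in place of chloro on an aromatic carbon. Compound 2 suggests that trifluoromethyl groups on this ring go with a lower number than compound 1 shows, yet compound 3 keeps one chloro and gains only a single trifluoromethyl, so the step is expected to be a moderate drop, a 2.1-fold lower number from compound 1 to compound 3 (0.33 log units; beyond the scatter), in this assay. Compound 3 is therefore expected to give about 5000 nM, somewhere between 2000 nM and 12000 nM.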

Compound 3, concentration for total growth inhibition: 2500 nM
The estimate for compound 3 lay 2.0-fold (0.30 log units) above the measured number, within the range that was stated.
By their numbers in this assay, from the lowest: compounds 3 and 2 (each within the scatter of the next); then compound 1.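

Compound 1 and compound 3 differ in one place only, so the change can be read by itself, which compound 2, with its different set of groups on that ring, did not allow. In this assay, putting trifluoromethyl in place of chloro on an aromatic carbon ortho to a chloro group gives a 4.2-fold lower number from compound 1 to compound 3 (0.63 log units; beyond the scatter), a modest step beyond the scatter, so a single swap at this position is enough to shift the number. Nothing shown here tells what lies behind the step.

On these data alone, whether other groups at this position, such as a nitrile, a methoxy group or an amine, would shift the number as well remains open. So does whether this step would hold in other cell lines.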